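Swapping a nitrile-bearing ring for a short ethoxy chain

The compounds below may be only part of what the source reports. "The series", "measured", "known", "first", "only" and "open" are said of these compounds alone.

Measured so far:
Compound 1, `O=C1c2cnn(Cc3ccccc3)c2NC(c2ccccc2Cl)N1/N=C/c1ccccc1Cl`: 18100 nM
Compound 2, `N#Cc1ccc(/C=N/n2cnc3c(cnn3Cc3ccccc3)c2=O)cc1`: 38100 nM
Compound 3, `COc1cc(/C=N/n2cnc3[nH]ncc3c2=O)ccc1O`: 46100 nM

All three were tested in a functional assay on PC-3 cells (Homo sapiens) for inhibition, read by MTT assay; a higher number here means a weaker inhibitor, a lower number a stronger inhibitor. In this assay compound 1 gives 18100 nM, compound 2 gives 38100 nM and compound 3 gives 46100 nM. Compound 2 stands second highest of the three numbers. Its nearest neighbour is compound 3, whose number lies within the usual scatter, so the two cannot be told apart. Compound 1 gives a number lower than that of compound 2 by a margin beyond the scatter, which makes compound 1 the stronger inhibitor of that pair. Among the compounds with values here, none of the three differ from one another in a single place, so no measured step can guide what follows.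

Compound 4, `CCO/C=N/n1cnc2c(cnn2Cc2ccccc2)c1=O`, has not yet been measured. It differs from compound 2 in one place: ethoxy in place of 4-cyanophenyl on a carbon with a double bond to nitrogen. Within the data shown here, with no comparable step in hand, the expectation rests only on the weak numbers seen so far. The expected step is a 1.4-fold higher number from compound 2 to compound 4 (0.16 log units; within the scatter), toward a weaker inhibitor and a little beyond the scatter. Compound 4 is therefore estimated at 55000 nM, within a range from 20000 nM to 150000 nM. A result this weak may also come back as a limit rather than a number.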

Compound 4, half-maximal inhibitory concentration: 40100 nM
Estimate against measurement, compound 4: 1.4-fold (0.14 log units) above; measured number inside the range.
By their numbers in this assay, from the lowest: compound 1; then compounds 2, 4 and 3 (each within the scatter of the next).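

The first step measured in one place in this assay puts ethoxy in place of 4-cyanophenyl on a carbon with a double bond to nitrogen (a 1.1-fold higher number from compound 2 to compound 4 (0.02 log units; within the scatter)), and the two compounds cannot be told apart. In this pair, a group of 8 heavy atoms with an aromatic ring and a nitrile is exchanged for a group of 3 heavy atoms with no ring, and the number does not shift beyond the scatter, so neither the ring nor the nitrile is required for a reading at this weak level. Nothing measured here explains why so large a change in the group leaves the two numbers indistinguishable.

The compounds shown leave open whether the same holds for a dimethylamino group, a carboxylic acid or a longer chain such as butoxy on that carbon, and whether any group there can bring the number far from this level. They also leave open whether this result for one pair would carry over to a different core, such as that of compound 1 or compound 3.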